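The compounds below may be only part of what the source reports. "The series", "measured", "known", "first", "only" and "open" are said of these compounds alone.

Working notes on the series.

Compound 1 `COc1ccc2c(=O)c(/C=C/C(=O)NCc3cccc(F)c3)coc2c1` sits second highest of the three numbers in a functional assay on Huh-7 cells (Homo sapiens) for inhibition, read by MTT assay, with a stated time of 48 h (on this read-out higher numbers stand for weaker inhibition and lower numbers for stronger inhibition), where compound 1 gives 10100 nM. Its nearest neighbour is compound 2 `Cc1ccccc1NC(=O)/C=C/c1coc2cc(O)ccc2c1=O`, which in this assay gives 11100 nM; the two lie within the scatter of each other. Furthest off is compound 3 `O=C(/C=C/c1coc2cc(O)ccc2c1=O)Nc1ccccc1`, which in this assay gives 3880 nM, a lower number than compound 1 and beyond the scatter.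

For the measured compounds named here, the one measured step that changes a single place, a 2.9-fold lower number from compound 2 to compound 3 (0.46 log units; beyond the scatter), concerns hydrogen in place of methyl on an aromatic carbon.

Compound 4 `COc1ccc2c(=O)c(/C=C/C(=O)Nc3ccc(C)cc3)coc2c1` differs from compound 1 as follows: 4-methylphenyl in place of 3-fluorobenzyl on an amide-type nitrogen. Going by the values given here, no measured step covers this change. It combines two separate moves that the measured compounds only touch in part: compound 1 carries a benzyl-type amide, while compound 2 and compound 3 carry aryl amides on a core that differs from that of compound 1 by a hydroxy instead of a methoxy. Compound 2, an aryl amide bearing a methyl, and compound 1 give numbers within the scatter of each other, so the aryl amide with a methyl is not clearly separated from the benzyl-type amide.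

The expectation for compound 4 is therefore a step of a 1.1-fold lower number from compound 1 to compound 4 (0.05 log units; within the scatter) that stays within the scatter. The estimate for compound 4 in this assay is 9000 nM, with a range of 3500 nM to 25000 nM.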

Compound 4, half-maximal inhibitory concentration: > 100000 nM
Compound 4 ended at the assay's limit (the forecaster's own chance of this, stated with the estimate: 10%); at least 11-fold (1.04 log units) between middle value and limit.
By their numbers in this assay, from the lowest: compound 3; then compounds 1 and 2 (each within the scatter of the next). At a limit, above all of these: compound 4.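

In this assay compound 4 gives > 100000 nM, which is a limit of the assay and not a number: the limit of > 100000 nM in this assay, at which 1 of the 4 values shown sits. On the core of compound 1, the group on the amide-type nitrogen therefore matters, with 4-methylphenyl in place of 3-fluorobenzyl giving an at least 9.9-fold higher number from compound 1 to compound 4 (0.99 log units; beyond the scatter), so that this step has a lower bound rather than a measured size. For the compounds shown here, the earlier compounds offered only one single-place step, a 2.9-fold lower number from compound 2 to compound 3 (0.46 log units; beyond the scatter), which concerned a methyl on an aromatic carbon of an aryl amide on the hydroxy core and said nothing about replacing the group on the amide-type nitrogen itself.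

The change to compound 4 alters several features in one move, so the compounds shown do not separate the contribution of the fluorine, the methyl and the benzyl carbon, and they give no true value for compound 4 beyond the limit. Also open, going by these compounds, is how the core of compound 1 responds to other groups on this nitrogen, such as an unsubstituted benzyl, a 2-phenylethyl chain or a phenyl ring bearing a carboxylic acid.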